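The compounds below may be only part of what the source reports. "The series", "measured", "known", "first", "only" and "open" are said of these compounds alone.

Three compounds share one core and differ only in the group carried on the ring nitrogen of the saturated six-membered ring: compound 1 `CCCn1c(=O)[nH]c2nc(-c3ccc(S(=O)(=O)N4CCN(Cc5cccc(C)c5)CC4)cc3)[nH]c2c1=O`, compound 2 `CCCn1c(=O)[nH]c2nc(-c3ccc(S(=O)(=O)N4CCN(C)CC4)cc3)[nH]c2c1=O` and compound 3 `CCCn1c(=O)[nH]c2nc(-c3ccc(S(=O)(=O)N4CCN(Cc5cccc(Br)c5)CC4)cc3)[nH]c2c1=O`. In an assay on CHO cells for displacement of a labelled ligand from adenosine receptor A3 (Homo sapiens), read by scintillation counting, with a stated time of 45 min, in the presence of a further agent that is not named here (a higher number here means a weaker inhibitor, a lower number a stronger inhibitor), compound 1 gives > 1000 nM, which is a limit of the assay and not a number. In this assay compound 2 gives > 1000 nM, again only a limit. In this assay compound 3 gives > 1000 nM, also a limit. Compound 3 therefore stands exactly where every value shown stands, at the limit of > 1000 nM in this assay, at which 3 of the 3 values shown sit. The steps a step that the two limits leave unreadable from compound 1 to compound 2, a step that the two limits leave unreadable from compound 1 to compound 3 and a step that the two limits leave unreadable from compound 2 to compound 3 cannot be given a size, since both ends of each sit at the limit of > 1000 nM in this assay, at which 3 of the 3 values shown sit.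

Compound 4 `CCCn1c(=O)[nH]c2nc(-c3ccc(S(=O)(=O)N4CCN(C(C)c5ccccc5)CC4)cc3)[nH]c2c1=O` differs from compound 3 in one place: 1-phenylethyl in place of 3-bromobenzyl on an amine nitrogen in a ring. All three measured steps bear on this change, as each swaps the group on the same ring nitrogen, yet none of them has a readable size or direction. Among the measured compounds shown here, no step in this assay beyond the scatter can be predicted from them in either direction; the only guide is that every neighbour so far sits at the limit. Compound 4 is thus expected to give about 3000 nM in this assay, with a range from 800 nM to 20000 nM. The expected step that the limit leaves unreadable from compound 3 to compound 4 is accordingly an estimate of no real change.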

Compound 4, inhibition constant: > 1000 nM
Compound 4 was reported as a limit; the forecaster's own chance of this, stated with the estimate: 80%; the middle value lies beyond the limit too.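

No step to compound 4 can be read from compound 1, compound 2 or compound 3, because both ends of each comparison are limits and not numbers: the limit of > 1000 nM in this assay, at which 4 of the 4 values shown sit.

The compounds shown leave open how strong an inhibitor each of the four is in this assay, and so whether the group on the ring nitrogen makes any difference there.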